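A few compounds are considered here, and "the series" means these few. Any claim that something is new, unique, unknown or untested is made for them only; others in the source may bear on it.

Measured compounds in a functional assay on CFPAC-1 cells (Homo sapiens) for antiproliferative activity, read by MTT assay, with a stated time of 72 h; a higher number here means a weaker inhibitor, a lower number a stronger inhibitor:
compound 1 `O=C1O[C@H]([C@@H](O)Cn2cc(-c3cccc(O)c3)nn2)C(OCc2ccccc2)=C1OCc1ccccc1` gives 54100 nM;
compound 2 `C[Si](C)(C)c1cn(C[C@H](O)[C@H]2OC(=O)C(OCc3ccccc3)=C2OCc2ccccc2)nn1` gives 52600 nM;
compound 3 `COc1ccc(-c2cn(C[C@H](O)[C@H]3OC(=O)C(OCc4ccccc4)=C3OCc3ccccc3)nn2)cc1` gives 26000 nM.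

Compound 3 holds the lowest of the three numbers in this assay, set apart from both neighbours by a 2.1-fold lower number from compound 1 to compound 3 (0.32 log units; beyond the scatter) and a 2.0-fold lower number from compound 2 to compound 3 (0.31 log units; beyond the scatter), each beyond the scatter, while the gap a 1.0-fold lower number from compound 1 to compound 2 (0.01 log units; within the scatter) stays within it. Compound 4 `O=C1O[C@H]([C@@H](O)Cn2cc(CNS(=O)(=O)c3ccc(Cl)cc3)nn2)C(OCc2ccccc2)=C1OCc1ccccc1` keeps the shared core and changes the same aromatic carbon of the five-membered aromatic ring with 3 nitrogen: (((4-chlorophenyl)sulfonyl)amino)methyl in place of 4-methoxyphenyl on an aromatic carbon. The two informative steps both replaced the group at that carbon and moved the number only modestly, so the step of a 1.3-fold higher number from compound 3 to compound 4 (0.13 log units; within the scatter) is expected to stay small, if anything toward a higher number. Compound 4 is estimated at 35000 nM, within 12000 nM to 100000 nM.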

Compound 4, half-maximal inhibitory concentration: 38900 nM
Beside the measured number, compound 4's estimate is 1.1-fold (0.05 log units) below it; measured number inside the range.
By their numbers in this assay, from the lowest: compounds 3, 4, 2 and 1 (each within the scatter of the next, the first and the last beyond it).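

In this assay, (((4-chlorophenyl)sulfonyl)amino)methyl on this aromatic carbon brings a hydrogen-bond donor that 4-methoxyphenyl lacks, yet every new step stays within the scatter: a 1.5-fold higher number from compound 3 to compound 4 (0.17 log units; within the scatter), a 1.4-fold lower number from compound 2 to compound 4 (0.13 log units; within the scatter) and a 1.4-fold lower number from compound 1 to compound 4 (0.14 log units; within the scatter). Compound 4 therefore cannot be separated from any earlier compound, although compound 1 and compound 3 differ beyond the scatter. No available evidence bears on this result.

As far as these compounds go, whether an amine, a carboxylic acid or a longer chain on this carbon would move the number beyond the scatter remains open.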